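The source may hold more compounds than are shown below. What is called first, only, known or untested is meant among the compounds shown, and "the series" means these compounds.

Measured so far:
- compound 1 `CCCc1ccc(NC2=CC(=O)c3c(nc4n3[C@H]3OC[C@@H](O)[C@H]3OC4)C2=O)cc1` — in a functional assay on MGC-803 cells (Homo sapiens) for inhibition, read by sulforhodamine B assay (on this read-out lower numbers stand for stronger inhibition and higher numbers for weaker inhibition), compound 1 gives 1920 nM
- compound 2 `Cc1ccc(NC2=CC(=O)c3c(nc4n3[C@H]3OC[C@@H](O)[C@H]3OC4)C2=O)cc1C` — compound 2 gives 1050 nM
- compound 3 `O=C1C=C(NCc2ccccc2)C(=O)c2c1nc1n2[C@H]2OC[C@@H](O)[C@H]2OC1` — compound 3 gives 2670 nM

Compound 3 has the highest of the three numbers. Against compound 1 the gap is within the scatter; against compound 2 it is beyond it, so compound 2 reads as stronger than compound 3, while compound 1 and compound 3 cannot be ordered.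

Among the compounds with values here, the only step measured on the shared core is a 1.8-fold lower number from compound 1 to compound 2 (0.26 log units; within the scatter), an exchange of one aryl group for another on the amine nitrogen, within the scatter.

Compound 4 `O=C1C=C(Nc2ccccc2)C(=O)c2c1nc1n2[C@H]2OC[C@@H](O)[C@H]2OC1` differs from compound 3 by phenyl in place of benzyl on an amine nitrogen. Within the data shown here, no measured pair covers this change; the step from compound 1 to compound 2 concerns two substituted phenyl groups and does not show what removing the methylene between nitrogen and ring does. Compound 4 carries an aryl directly on the nitrogen, as compound 1 and compound 2 do, and their values sit at or below that of compound 3, so a number in that same region is expected, with an expected step of a 1.5-fold lower number from compound 3 to compound 4 (0.17 log units; within the scatter) that may well stay within the scatter. Compound 4 is therefore estimated at 1800 nM in this assay, in the range 800 nM to 4000 nM.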

Compound 4, half-maximal inhibitory concentration: 1730 nM
Compound 4: middle estimate off by 1.0-fold (0.02 log units), on the high side; measured number inside the range.
By their numbers in this assay, from the lowest: compounds 2, 4, 1 and 3 (each within the scatter of the next, the first and the last beyond it).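

In this assay, within the data shown here, the pair of compound 3 and compound 4 is the first to test the size of the group on the amine nitrogen rather than the decoration of an aryl ring, and the exchange of benzylamino for anilino gives a 1.5-fold lower number from compound 3 to compound 4 (0.19 log units; within the scatter). On this pair, then, the position does not separate benzyl from phenyl, so the aromatic ring can sit directly on the amine nitrogen or one carbon further out without a difference that can be told from the scatter. No measurement at hand offers an explanation for this small step.

On these data alone, it remains open whether this insensitivity extends to a longer chain such as phenethyl, to a simple alkyl group such as cyclohexyl that carries no aromatic ring, or to a basic group such as a dimethylaminoethyl chain on the same nitrogen. Equally open, as far as these compounds go, is how a methoxy group, a chlorine or a carboxylic acid on the phenyl ring of compound 4 or on the benzyl ring of compound 3 would read in this assay.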